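From Methylamino to Dimethylamino in Compound 1

The source may report more compounds than this note shows. Statements on the series, on what has been measured and on what is new or still open speak of the compounds shown alone.

Among the measured compounds shown here, in a physicochemical assay for lipophilicity (a higher number here means a more lipophilic compound, a lower number a more polar compound), compound 1 `CNc1ccc(-c2nc3ccc(OC)cc3s2)cn1` gives 3.2, the higher of the two numbers so far. Compound 2 `CN(C)c1ccc(-c2nc3ccc(O)cc3s2)cn1` gives 2.4, a gap larger than the usual scatter between repeat measurements. Compound 3 `COc1ccc2nc(-c3ccc(N(C)C)nc3)sc2c1` has not yet been measured. Its structure differs from that of compound 1 in one place, shown by methyl in place of hydrogen on a nitrogen on an aromatic ring, which turns methylamino into dimethylamino. For the measured compounds named here, no two measured compounds differ in only one place, so no measured step can serve as a guide, and the expectation rests on the structural change alone. The expected change, a number 0.40 log units higher from compound 1 to compound 3 (beyond the scatter), is a modest rise in this assay, slightly beyond the scatter. For compound 3 the estimate is 3.6, with an expected range from 3.2 to 4.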

Compound 3, distribution coefficient: 4.2
Compound 3: the middle estimate sits 0.60 log units below what was measured; the measured number lies above the stated range.
By their numbers in this assay, from the lowest: compound 2; then compound 1; then compound 3.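

Putting methyl in place of hydrogen on the nitrogen, which turns methylamino into dimethylamino, gives a number 1.00 log units higher from compound 1 to compound 3 (beyond the scatter) in this assay and shows that this position can move the number by a clear margin. Methyl in place of hydrogen on an oxygen on an aromatic ring gives a number 1.80 log units higher from compound 2 to compound 3 (beyond the scatter) and counts as a large step where the change on the nitrogen counts as modest, so in this set the methyl on the oxygen moves the number further. No measurement shown here explains the size of either step. Going by these compounds, each change appears only once, on this one core, so it remains open whether the same methyl would give a similar step on another compound. On these data alone, whether ethyl or a longer chain on the same nitrogen would raise the number further also remains open.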